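Dropping the methoxy from compound 2

The compounds below may be only part of what the source reports. "The series", "measured", "known", "first", "only" and "open" are said of these compounds alone.

In a functional assay on NCI-H23 cells (Homo sapiens) for antiproliferative activity (on this read-out higher numbers stand for weaker inhibition of growth and lower numbers for stronger inhibition of growth), compound 2 `COc1ccccc1CN1CC=C(CCC(=O)NO)C1=O` gives 6130 nM, the highest of the three numbers recorded. Compound 1 `COc1cccc(CN2CC=C(CCC(=O)NO)C2=O)c1` gives 1970 nM, a gap beyond the scatter, while compound 3 `COc1ccccc1CCCN1CC=C(CCC(=O)NO)C1=O` gives 4490 nM, which lies within the scatter of compound 2. Compound 4 `O=C(CCC1=CCN(Cc2ccccc2)C1=O)NO` has not yet been measured in this assay. It differs from compound 2 by hydrogen in place of methoxy on an aromatic carbon, the change sitting on an aromatic carbon of a six-membered aromatic ring of carbon only, ortho to a large group. Among the compounds with values here, no pair of measured compounds isolates this single change, so the expectation rests on the spread of the measured numbers alone. Compound 4 is expected to show a step of a 1.5-fold lower number from compound 2 to compound 4 (0.19 log units; within the scatter), a small shift within the scatter. In this assay compound 4 is estimated at 4000 nM, within a range from 1500 nM to 11000 nM.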

Compound 4, concentration for 50% growth inhibition: 4290 nM
Compound 4: middle estimate off by 1.1-fold (0.03 log units), on the low side; low and high end bracket the measured number.
By their numbers in this assay, from the lowest: compound 1; then compounds 4, 3 and 2 (each within the scatter of the next).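

In this assay hydrogen in place of methoxy on an aromatic carbon, ortho to a large group, gives a 1.4-fold lower number from compound 2 to compound 4 (0.16 log units; within the scatter) and so leaves the number of compound 2 effectively unchanged. The same kind of exchange gives a 2.2-fold higher number from compound 1 to compound 4 (0.34 log units; beyond the scatter) and so a modest loss appears only when the methoxy of compound 1 is the one removed. Nothing measured here explains why the two methoxy compounds differ in this way.
Going by these compounds, what remains open is whether an amine or a carboxylic acid on that aromatic carbon would move the number beyond the scatter of compound 4.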